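Methyl additions and whole-animal dose: notes on three compounds

The compounds below may be only part of what the source reports. "The series", "measured", "known", "first", "only" and "open" are said of these compounds alone.

Measured so far in a functional assay on the whole organism (Cricetulus griseus) with Cricetinae gen. sp. as the target; on this read-out lower numbers stand for an effect already at smaller amounts and higher numbers for an effect only at larger amounts of compound:
- compound 1 `Cc1ccc(-c2n[nH]c(-c3ccccc3)n2)cc1`: > 20 mg/kg
- compound 2 `COc1cccc(-c2n[nH]c(-c3ccccc3C)n2)c1`: 0.08 mg/kg
- compound 3 `COc1cccc(-c2n[nH]c(-c3cc(C)ccc3C)n2)c1`: 2.5 mg/kg

The value recorded for compound 1 is a limit of this assay and not a number; it is the limit of > 20 mg/kg in this assay, at which 1 of the 3 values shown sits. Compound 2 gives 0.08 mg/kg in this assay, and compound 3 gives 2.5 mg/kg. The two differ in one place, (methyl in place of hydrogen on an aromatic carbon), and that step is a 31-fold higher number from compound 2 to compound 3 (1.49 log units; beyond the scatter). How the core of compound 1 differs from the core of compound 2 is not broken down here.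

Still to be measured is compound 4 `Cc1ccc(-c2n[nH]c(-c3ccccc3C)n2)cc1`. It differs from compound 1 by methyl in place of hydrogen on an aromatic carbon. Among the measured compounds shown here, this is the same kind of change as the one from compound 2 to compound 3, but not the same change: there the entering methyl sits meta to a large group and para to a methyl group, here it sits ortho to a large group, so the measured step is only a loose guide.

For the measured compounds named here, because compound 1 in this assay shows only > 20 mg/kg, a limit, the starting point for compound 4 is itself uncertain, and the one measured step of this kind, a 31-fold higher number from compound 2 to compound 3 (1.49 log units; beyond the scatter), moved the number upward. For compound 4 the expected step is therefore an at least 1.6-fold lower number from compound 1 to compound 4 (0.22 log units; that floor lies within the scatter), carrying a wide range. Compound 4 is expected to give about 12 mg/kg in this assay, plausibly between 1.5 mg/kg and 40 mg/kg, with a real chance that the assay again reports only a limit.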

Compound 4, dose for half-maximal effect: 20 mg/kg
Compound 4: the middle estimate sits 1.7-fold (0.22 log units) below what was measured; the range from low to high includes it.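

In this assay, methyl in place of hydrogen on an aromatic carbon does not carry over from one core to the other as a step of one size: the same change on two cores in this assay, a 31-fold higher number (1.49 log units; beyond the scatter) from compound 2 to compound 3 and a number no higher (the limit leaves the size open) from compound 1 to compound 4, at least 31-fold (1.49 log units) apart, beyond the scatter of two such steps. Compound 1 stands at a limit of the assay and not at a number: the limit of > 20 mg/kg in this assay, at which 1 of the 4 values shown sits. The step on this core reads as a number no higher from compound 1 to compound 4 (the limit leaves the size open) and its size therefore cannot be read, and the two steps differ both in their core and in where the methyl enters, so the gap shows that this change cannot simply be transferred within the series but does not show which of those differences accounts for it.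

The compounds shown vary only methyl and methoxy groups on the aromatic rings, so it remains open how a chlorine, a nitrile or a carboxylic acid in the place ortho to a large group would read in this assay. Also open, as far as these compounds go, is whether the large step seen on the core of compound 2 would recur on that core with a methyl entering elsewhere on the ring, and what number lies behind the limit for compound 1.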